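Moving a Hydroxy Group: Expectation for Compound 4

The source may hold more compounds than are shown below. What is called first, only, known or untested is meant among the compounds shown, and "the series" means these compounds.

Compound 1 `O=C(N/N=C/c1ccc(O)cc1)c1cnccn1` gives 43.1% in a functional assay on the whole organism (strain Swiss) for inhibition, with Mus musculus as the target, with stated times of 40 min and 6 h, at a dose of 100 mg/kg by the oral route; on this read-out higher numbers stand for more inhibition at the one dose given (going by the name of the read-out) and lower numbers for less inhibition.
Compound 2 `O=C(N/N=C/c1ccccc1)c1cnccn1` gives 21.7% in this assay.
Compound 3 `CC(C)c1ccc(/C=N/NC(=O)c2cnccn2)cc1` gives 19.4% in this assay.

Compound 2 stands second highest of the three: its value and that of compound 3 lie within the scatter of each other, while compound 1 is clearly higher. Compound 4 `O=C(N/N=C/c1ccccc1O)c1cnccn1` differs from compound 2 by hydroxy in place of hydrogen on an aromatic carbon. For the measured compounds named here, the one measured step that bears on this change is a number 21.4 percentage points lower from compound 1 to compound 2 (beyond the scatter), where a hydroxy leaving the aromatic ring lowered the read-out. Here a hydroxy enters again, though where it sits differs from compound 1, so a modest rise in this assay is expected, with wide uncertainty. Compound 4 is estimated at 33%, between 18% and 48%, an expected step of a number 11.3 percentage points higher from compound 2 to compound 4 (beyond the scatter).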

Compound 4, a percentage reported as inhibition, in the whole organism at one dose (the size of the read-out at that dose, not a potency): 51.2%
The estimate for compound 4 lay 18.2 percentage points below the measured number; the measured number lies above the stated range.
By their numbers in this assay, from the lowest: compounds 3 and 2 (each within the scatter of the next); then compounds 1 and 4 (each within the scatter of the next).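

In this assay, hydroxy in place of hydrogen ortho to a large group brings a clear gain, a number 29.5 percentage points higher from compound 2 to compound 4 (beyond the scatter), so a rise on adding hydroxy to this ring is not confined to the place it holds in compound 1. Compound 1 at 43.1% and compound 4 at 51.2% lie within the scatter of each other, so these two places cannot be told apart here. Nothing available explains the rise.

As far as these compounds go, whether the gain is particular to hydroxy remains open. A methoxy group or an amine at the same place would test this.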